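Ester replaces acetamide: another large drop in stability expected

The source may hold more compounds than are shown below. What is called first, only, known or untested is meant among the compounds shown, and "the series" means these compounds.

Compound 1 `CC(=O)NC1CCC(CN2CCN(c3cc(=O)c4cc(C(F)(F)F)cc([N+](=O)[O-])c4s3)CC2)CC1` carries an acetamido group on a saturated ring carbon. In an ADME assay on cells (Hepatocyte, Mus musculus) for metabolic stability (on this read-out lower numbers stand for a shorter-lived compound and higher numbers for a longer-lived compound), compound 1 gives > 1.55 h, which is a limit of the assay and not a number. This sits at the limit of > 1.55 h in this assay, at which 1 of the 3 values shown sits. Compound 2 `O=C(OC1CCC(CN2CCN(c3cc(=O)c4cc(C(F)(F)F)cc([N+](=O)[O-])c4s3)CC2)CC1)c1ccc(F)cc1` gives 0.0817 h in this assay, and compound 3 `O=C(OC1CCC(CN2CCN(c3cc(=O)c4cc(C(F)(F)F)cc([N+](=O)[O-])c4s3)CC2)CC1)c1cccs1` gives 0.0867 h. Both replace the acetamido with an aromatic ester, and both steps were large: an at least 18-fold lower number from compound 1 to compound 2 (1.27 log units; beyond the scatter) and an at least 17-fold lower number from compound 1 to compound 3 (1.25 log units; beyond the scatter). Between the two esters the gap is small, a 1.1-fold higher number from compound 2 to compound 3 (0.03 log units; within the scatter), so the ring on the carbonyl carbon made no difference that could be told from the scatter.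

Compound 4 `O=C(OC1CCC(CN2CCN(c3cc(=O)c4cc(C(F)(F)F)cc([N+](=O)[O-])c4s3)CC2)CC1)c1ccncc1` follows the same route: ((pyridin-4-yl)carbonyl)oxy in place of acetamido on a saturated ring carbon. The two measured ester steps from compound 1 both fell far, and the pyridine ester is expected to behave like them, so a large downward step is estimated, an at least 17-fold lower number from compound 1 to compound 4 (1.23 log units; beyond the scatter). Compound 4 is accordingly expected to give 0.09 h, with a range from 0.04 h to 0.25 h.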

Compound 4, half-life: 0.0817 h
Estimate against measurement, compound 4: 1.1-fold (0.04 log units) above; measured number inside the range.
By their numbers in this assay, from the lowest: compounds 2, 4 and 3 (each within the scatter of the next). At a limit, above all of these: compound 1.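

With a basic-free description set aside, the pyridin-4-yl ester behaves as the other two esters do, and replacing the acetamido on the saturated ring carbon again gives an at least 18-fold lower number from compound 1 to compound 4 (1.27 log units; beyond the scatter). The nitrogen in the ring on the carbonyl carbon leaves no mark that can be told from the scatter, with no change at the digits printed from compound 2 to compound 4 (within the scatter) and a 1.1-fold lower number from compound 3 to compound 4 (0.03 log units; within the scatter), so the 4-fluorophenyl, thiophen-2-yl and pyridin-4-yl esters now form one group of compounds 2, 3 and 4. The size of the step from the acetamide is only a bound, as compound 1 stands at a limit of the assay: the limit of > 1.55 h in this assay, at which 1 of the 4 values shown sits.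

The compounds shown leave open whether the fall goes with the ester link or with the aromatic ring on the carbonyl carbon. An amide carrying the pyridin-4-yl ring, or an acetate ester at the same ring carbon, would separate the two.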